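A few compounds are considered here, and "the series" means these few. Any claim that something is new, unique, unknown or untested is made for them only; others in the source may bear on it.

Measured in a functional assay on DU-145 cells (Homo sapiens) for inhibition, read by trypan blue exclusion, with a stated time of 72 h; on this read-out higher numbers stand for weaker inhibition and lower numbers for stronger inhibition:
Compound 1 `Cn1c(=O)c(S(=O)(=O)Cc2ccc(F)cc2)cc2cnc(Nc3ccc4[nH]ccc4c3)nc21`: 30000 nM
Compound 2 `COc1ccc(S(=O)(=O)c2cc3cnc(Nc4cccc5[nH]ccc45)nc3n(C)c2=O)cc1`: 5000 nM
Compound 3 `Cc1ccc(S(=O)(=O)c2cc3cnc(Nc4cnc5[nH]ccc5c4)nc3n(C)c2=O)cc1`: 25000 nM

Compound 1 at 30000 nM and compound 3 at 25000 nM lie within the scatter of each other. Compound 2 at 5000 nM has a lower number than compound 1, a gap beyond the scatter, and so shows stronger inhibition. Compound 1 therefore sits at the weak end of this small set, level with compound 3.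

The next compound to read is compound 4 `Cn1c(=O)c(S(=O)(=O)Nc2ccc(F)cc2)cc2cnc(Nc3ccc4[nH]ccc4c3)nc21`. It keeps the core of compound 1 and changes one group: (4-fluorophenyl)amino in place of 4-fluorobenzyl on a sulfonyl sulfur.

Among the compounds with values here, the measured compounds each differ in more than one place, so no measured step isolates this change. Within the data shown here, with no such precedent, no step beyond the scatter is expected in this assay, and any shift is expected to be towards a slightly lower number. The wide range allows for the gap seen with compound 2 at 5000 nM. The expected move is a 1.5-fold lower number from compound 1 to compound 4 (0.18 log units; within the scatter), which stays within the scatter. For compound 4 the estimated value is 20000 nM, with an expected range from 5000 nM to 50000 nM.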

Compound 4, half-maximal inhibitory concentration: 5000 nM
For compound 4 the middle estimate is 4.0-fold (0.60 log units) above the measured one, and the stated range covers the measured number.
By their numbers in this assay, from the lowest: compounds 2 and 4 (each within the scatter of the next); then compounds 3 and 1 (each within the scatter of the next).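

In this assay, within the data shown here, the only change read in one place so far gives a 6.0-fold lower number from compound 1 to compound 4 (0.78 log units; beyond the scatter), so what sits on this sulfonyl sulfur matters for inhibition in these cells. The 4-fluorobenzyl and (4-fluorophenyl)amino groups have the same count of heavy atoms and each carries one six-membered aromatic ring of carbon only, yet the step lies beyond the scatter. They differ in that one carbon gives way to one nitrogen and the entering group counts one hydrogen-bond donor where the leaving group counts none, but no measurement here says what lies behind the shift.

Still open, going by these compounds, is whether the nitrogen's hydrogen is needed: a methyl group on that nitrogen would test this, and a morpholine or a plain amine in place of (4-fluorophenyl)amino would show how much of the aromatic group can be changed. Also open, on these data alone, is whether the same exchange would act alike on compound 2 and compound 3, which differ from compound 1 in more than one place.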